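The source may hold more compounds than are shown below. What is called first, only, known or untested is meant among the compounds shown, and "the series" means these compounds.

Compound 1 `Nc1ccccc1NC(=O)c1ccc(NC(=S)NCc2cncc(Br)c2)cc1` is a thiourea-linked benzamide, and in a functional assay on MDA-MB-231 cells (Homo sapiens) for cytotoxicity, read by MTT assay, with a stated time of 72 h (on this read-out higher numbers stand for weaker inhibition and lower numbers for stronger inhibition), compound 1 gives 39000 nM. This is the lowest of the three numbers in hand, though compound 3 `Nc1ccccc1NC(=O)c1ccc(CNC(=O)c2cc3cnccc3[nH]2)cc1`, which gives 48000 nM, sits within the usual scatter of it. Going by the values given here, compound 2 `Nc1ccccc1NC(=O)c1ccc(NC(=S)NCc2cncc(F)c2)cc1` gives 85000 nM; the step of a 2.2-fold higher number from compound 1 to compound 2 (0.34 log units; beyond the scatter) is the only measured change that bears on the question here, and it shows a modest move from a fluoro in place of bromo on an aromatic carbon.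

Compound 4 `Nc1ccccc1NC(=O)c1ccc(NC(=S)NCc2cccc(Cl)c2)cc1` differs from compound 1 by 3-chlorophenyl in place of 5-bromopyridin-3-yl on a saturated chain carbon bound to an amide-type nitrogen. Among the compounds with values here, no measured pair shows a six-membered aromatic ring with one hetero atom being exchanged for a ring of carbon only, so the only guide is the halogen swap above, which was modest in size. The step of a 1.0-fold higher number from compound 1 to compound 4 (0.01 log units; within the scatter) is therefore expected to be small, with no clear direction beyond the scatter. Compound 4 is estimated to give 40000 nM, between 15000 nM and 100000 nM.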

Compound 4, half-maximal inhibitory concentration: 92000 nM
Beside the measured number, compound 4's estimate is 2.3-fold (0.36 log units) below it, within the range that was stated.
By their numbers in this assay, from the lowest: compounds 1, 3, 2 and 4 (each within the scatter of the next, the first and the last beyond it).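

In this assay, 3-chlorophenyl in place of 5-bromopyridin-3-yl on a saturated chain carbon bound to an amide-type nitrogen gives a 2.4-fold higher number from compound 1 to compound 4 (0.37 log units; beyond the scatter), so this place responds to an exchange of the whole aromatic ring and not only to a halogen swap on it. The matching exchange from the fluoro compound gives a 1.1-fold higher number from compound 2 to compound 4 (0.03 log units; within the scatter), which leaves those two compounds within the scatter of each other, and since ring and halogen change together in both steps, neither can be credited alone. No evidence in hand accounts for either step.

The compounds shown leave open whether 3-bromophenyl or 5-chloropyridin-3-yl would separate the effect of the ring from that of the halogen. They also leave open how an amine or a carboxylic acid on this ring would read in this assay.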